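The compounds below may be only part of what the source reports. "The series", "measured", "known", "first", "only" and "open" are said of these compounds alone.

The measured compounds:
compound 1, `Cc1ccc(-c2ccsc2S(=O)(=O)NCCNC(=O)Nc2cccc([N+](=O)[O-])c2)c(Oc2ccc(O)c(O)c2)c1`, which in a functional assay on RS4-11 cells (Homo sapiens) for inhibition, read by CCK-8 assay, with a stated time of 48 h (on this read-out higher numbers stand for weaker inhibition and lower numbers for stronger inhibition), gives 9100 nM
compound 2, `Cc1ccc(-c2ccsc2S(=O)(=O)NCCNC(=O)Nc2ccc([N+](=O)[O-])cc2)c(Oc2ccc(O)c(O)c2)c1`, which in this assay gives 7700 nM

Compound 2 has the smaller of the two numbers, yet the step of a 1.2-fold lower number from compound 1 to compound 2 (0.07 log units; within the scatter) shows that compound 2 and compound 1 sit within the scatter of each other, so neither can be called the stronger inhibitor on these data.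

Compound 3, `Cc1ccc(-c2ccsc2S(=O)(=O)NCCNC(=O)Nc2cc(Cl)cc(Cl)c2)c(Oc2ccc(O)c(O)c2)c1`, has not yet been measured. Its change from compound 2 is 3,5-dichlorophenyl in place of 4-nitrophenyl on an amide-type nitrogen. Within the data shown here, the only measured step, a 1.2-fold lower number from compound 1 to compound 2 (0.07 log units; within the scatter), moved the nitro group to another position on the ring and stayed within the scatter; it tells nothing about exchanging the nitro group for two chlorine atoms, so no measured step bears directly on this change. Among the measured compounds shown here, with no precedent, the expected step of a 1.1-fold lower number from compound 2 to compound 3 (0.04 log units; within the scatter) is taken to lie within the scatter, with a wide range. Compound 3 is therefore estimated at 7000 nM, between 2500 nM and 20000 nM.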

Compound 3, half-maximal inhibitory concentration: 5100 nM
The estimate for compound 3 lay 1.4-fold (0.14 log units) above the measured number; the range from low to high includes it.
By their numbers in this assay, from the lowest: compounds 3, 2 and 1 (each within the scatter of the next).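

Compound 3 shows that a nitro group on this ring is not required for a number in the same range in this assay, since a ring bearing only chlorine atoms on the amide-type nitrogen reads alike. Exchanging 4-nitrophenyl for 3,5-dichlorophenyl (a 1.5-fold lower number from compound 2 to compound 3 (0.18 log units; within the scatter)) and exchanging 3-nitrophenyl for it (a 1.8-fold lower number from compound 1 to compound 3 (0.25 log units; within the scatter)) both stay within the scatter, so these three groups cannot be ranked against one another. No measurement shown here offers an explanation for this result.

Every group shown on this nitrogen is a phenyl ring carrying nitro or chlorine, so it remains open how a ring carrying an amine or a carboxylic acid would read. As far as these compounds go, it also remains open whether any change at this position can move the number beyond the scatter.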